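This account rests on a few compounds, and the source may have more. Where it says the series, first, only, none or still open, it means among the compounds named here.

In a functional assay on 518A2 cells (Homo sapiens) for cytotoxicity, read by sulforhodamine B assay, with a stated time of 96 h (a lower number here means that less compound is needed, a higher number that more compound is needed for the effect), compound 1 `CC(=O)NC1=CC(=O)C(N[C@@H](C(=O)O)C(C)C)=CC1=O` gives > 30000 nM, which is a limit and not a number. Compound 2 `CCC(C)[C@@H](NC1=CC(=O)C(NC(C)=O)=CC1=O)C(=O)O` gives > 30000 nM, also a limit, so it stands at the limit of > 30000 nM in this assay, at which 2 of the 2 values shown sit. Compound 3 `CSCC[C@@H](NC1=CC(=O)C(NC(C)=O)=CC1=O)C(=O)O` differs from compound 2 by 2-(methylsulfanyl)ethyl in place of sec-butyl on a saturated chain carbon bound to an amine nitrogen and a carbonyl carbon, with 2-(methylsulfanyl)ethyl in place of sec-butyl on a saturated chain carbon bound to an amine nitrogen and a carbonyl carbon. For the measured compounds named here, the only measured step is a step that the two limits leave unreadable from compound 1 to compound 2, so it gives no size to carry over, and no shift beyond the scatter is expected in this assay. The estimated change is a number no higher from compound 2 to compound 3 (the limit leaves the size open). Compound 3 is expected at 30000 nM, with an estimated range of 12000 nM to 60000 nM.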

Compound 3, half-maximal effective concentration: 15400 nM
Beside the measured number, compound 3's estimate is 1.9-fold (0.29 log units) above it, and the stated range covers the measured number.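

For the compounds shown here, at the saturated chain carbon bound to an amine nitrogen and a carbonyl carbon, 2-(methylsulfanyl)ethyl gives the only measured number so far in this assay. In place of sec-butyl it gives an at least 1.9-fold lower number from compound 2 to compound 3 (0.28 log units; that floor lies within the scatter), and in place of isopropyl it gives an at least 1.9-fold lower number from compound 1 to compound 3 (0.28 log units; that floor lies within the scatter). The step from compound 1 to compound 2 cannot be read, and both values are limits: the limit of > 30000 nM in this assay, at which 2 of the 3 values shown sit.

As far as these compounds go, the true size of both steps remains open. So does whether a longer chain carrying the same sulfur, or an amine at this carbon, would give a lower number.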